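The source may hold more compounds than are shown below. What is called first, only, known or untested is meant among the compounds shown, and "the series" means these compounds.

Within the data shown here, compound 2 `COc1ccc(Nc2nccc(-c3sc(SCc4cccnc4)nc3C)n2)c(OC)c1` gives 270 nM in a functional assay on MV4-11 cells (Homo sapiens) for inhibition, read by resazurin assay, with a stated time of 72 h (a higher number here means a weaker inhibitor of growth, a lower number a stronger inhibitor of growth), and stands lowest of the two numbers measured so far; its nearest neighbour is compound 1 `COCCSc1nc(C)c(-c2ccnc(Nc3ccc(OC)cc3OC)n2)s1`, which in this assay gives 810 nM. Among the measured compounds shown here, the one measured step, a 3.0-fold lower number from compound 1 to compound 2 (0.48 log units; beyond the scatter), alters the chain on the same aromatic carbon that is changed next, and it is the only step that bears on the new compound. Compound 3 `CCCCOc1nc(C)c(-c2ccnc(Nc3ccc(OC)cc3OC)n2)s1` differs from compound 2 by butoxy in place of ((pyridin-3-yl)methyl)sulfanyl on an aromatic carbon, on an aromatic carbon of a five-membered aromatic ring with 1 nitrogen and 1 sulfur. The butoxy of compound 3 has no ring, so it resembles the chain of compound 1 more than the pyridin-3-yl-bearing chain of compound 2, and the gain that chain brought was modest. The number for compound 3 is therefore expected to move partly back toward compound 1, by about a 2.4-fold higher number from compound 2 to compound 3 (0.38 log units; beyond the scatter). The estimate for compound 3 is 650 nM, with a range from 250 nM to 1800 nM.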

Compound 3, concentration for 50% growth inhibition: 7860 nM
Compound 3: the middle estimate sits 12-fold (1.08 log units) below what was measured; the whole stated range lies below it.
By their numbers in this assay, from the lowest: compound 2; then compound 1; then compound 3.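

At this aromatic carbon of the shared core, the change in this assay can be much larger than the earlier step suggested: butoxy in place of ((pyridin-3-yl)methyl)sulfanyl gives (a 29-fold higher number from compound 2 to compound 3 (1.46 log units; beyond the scatter)), and butoxy in place of (2-methoxyethyl)sulfanyl gives (a 9.7-fold higher number from compound 1 to compound 3 (0.99 log units; beyond the scatter)). Loss of the ring alone therefore does not describe this position, since compound 1 and compound 3 both carry a chain with no ring and still stand apart beyond the scatter. Among these compounds, compound 3 is also the only compound here with its chain joined through oxygen rather than sulfur, so the linking atom and the chain change together in both steps.

Butylsulfanyl and (pyridin-3-yl)methoxy at this carbon would separate those two changes. Going by these compounds, whether a butylamino chain behaves like either link remains open. Nothing available here bears on the reason for the higher number.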